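Changing the Group on the Amine Nitrogen: Compound 4

The source may hold more compounds than are shown below. What is called first, only, known or untested is meant among the compounds shown, and "the series" means these compounds.

Measured so far in a functional assay on MCF7 cells (Homo sapiens) for inhibition, read by MTT assay, with a stated time of 48 h; on this read-out higher numbers stand for weaker inhibition and lower numbers for stronger inhibition:
- compound 1, `CCOC(=O)C1=C(N/N=C(\C#N)C(N)=O)Nc2[nH]nc(C)c2C1c1ccc(N(C)C)cc1`, gives 50100 nM
- compound 2, `CCOC(=O)C1=C(N)Nc2[nH]nc(C)c2C1c1ccc(N(C)C)cc1`, gives 5060 nM
- compound 3, `CCOC(=O)C1=C(N/N=C(/C(=O)Br)c2ccc(Cl)cc2)Nc2[nH]nc(C)c2C1c1ccc(N(C)C)cc1`, gives 46300 nM

Compound 3 sits second highest of the three numbers. Among the measured compounds shown here, one of its steps lies within the scatter (a 1.1-fold lower number from compound 1 to compound 3 (0.03 log units; within the scatter)) and the other beyond it (a 9.2-fold higher number from compound 2 to compound 3 (0.96 log units; beyond the scatter)); compound 2 is the only compound here with a bare hydrogen on the amine nitrogen. Compound 1 shows the same picture against compound 2 (a 9.9-fold lower number from compound 1 to compound 2 (1.00 log units; beyond the scatter)).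

Compound 4, `CCOC(=O)C(=NNC1=C(C(=O)OCC)C(c2ccc(N(C)C)cc2)c2c(C)n[nH]c2N1)C(=O)OCC`, keeps a substituent on that nitrogen but exchanges it: a group of 12 heavy atoms (7 carbon, 1 nitrogen, 4 oxygen; no ring) in place of a group of 12 heavy atoms (8 carbon, 1 nitrogen, 1 oxygen, 1 chlorine, 1 bromine; one six-membered aromatic ring of carbon only), on an amine nitrogen. For the measured compounds named here, the step that bears most directly is the one from compound 1 to compound 3, where one such group replaced another and the number barely moved. The two steps from compound 2 show that any group on that nitrogen, so far, goes with a higher number than the free amine. Compound 4 is therefore expected to stay near compounds 1 and 3, with a step in this assay of a 1.0-fold lower number from compound 3 to compound 4 (0.01 log units; within the scatter), which is no change beyond the scatter. The estimate for compound 4 is 45000 nM, within a range of 15000 nM to 130000 nM.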

Compound 4, half-maximal inhibitory concentration: 89800 nM
Estimate against measurement, compound 4: 2.0-fold (0.30 log units) below; the range from low to high includes it.
By their numbers in this assay, from the lowest: compound 2; then compounds 3, 1 and 4 (each within the scatter of the next).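

In this assay the group of 12 heavy atoms (7 carbon, 1 nitrogen, 4 oxygen; no ring) adds a third kind of substituent on the amine nitrogen, and replacing the aromatic group of compound 3 with it gives a 1.9-fold higher number from compound 3 to compound 4 (0.29 log units; within the scatter) while replacing the nitrile-bearing group of compound 1 gives a 1.8-fold higher number from compound 1 to compound 4 (0.25 log units; within the scatter). Compounds 1, 3 and 4 therefore cannot be told apart here, even though only compound 3 carries a six-membered aromatic ring, a chlorine and a bromine, whereas the free amine stays clearly separate, with an 18-fold higher number from compound 2 to compound 4 (1.25 log units; beyond the scatter), leaving compound 2 the most potent of the four. Nothing available explains why these three different groups give such similar numbers or why all three stand apart from the free amine.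

The compounds shown span only a bare hydrogen and groups of considerable size, so it remains open how the number would respond to something small on this nitrogen, such as a methyl or an acetyl group. A group carrying a carboxylic acid or a basic amine at this position would also test whether the similarity among compounds 1, 3 and 4 extends beyond these three substituents.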